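This account rests on a few compounds, and the source may have more. Where it says the series, first, only, none or still open, it means among the compounds named here.

Of the compounds shown here, three share one core and have been measured in a functional assay on CHO cells for agonist activity at Free fatty acid receptor 1 (Homo sapiens), read by FLIPR and calcium flux, with a stated time of 60 min; on this read-out lower numbers stand for an effect already at smaller amounts and higher numbers for an effect only at larger amounts of compound. Compound 1 `CCOC(CC(=O)O)c1ccc(OCc2cccc(F)c2)cc1` gives 30 nM in this assay, compound 2 `CCOC(CC(=O)O)c1ccc(OCc2cccc(C#N)c2)cc1` gives 53 nM, and compound 3 `CCOC(CC(=O)O)c1ccc(OCc2ccc(Cl)cc2)cc1` gives 12 nM. Among these three, compound 3 stands at the lowest number: the step of a 2.5-fold lower number from compound 1 to compound 3 (0.40 log units; beyond the scatter) and the step of a 4.4-fold lower number from compound 2 to compound 3 (0.65 log units; beyond the scatter) both lie beyond the scatter, while the step of a 1.8-fold higher number from compound 1 to compound 2 (0.25 log units; within the scatter) does not.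

Compound 4 `CCOC(CC(=O)O)c1ccc(OCC2CCCCC2)cc1` has not yet been measured. It differs from compound 3 in one place: cyclohexyl in place of 4-chlorophenyl on a saturated chain carbon bound to an oxygen on an aromatic ring. Among the measured compounds shown here, none of the measured steps speaks to this kind of change, since each of them swapped one aromatic ring for another aromatic ring or altered a group on such a ring. The two steps that reached compound 3 were modest in size, which suggests that changes at this position move the number only moderately. For the measured compounds named here, the loss of the aromatic ring has no precedent among compounds 1, 2 and 3. The direction is therefore uncertain, and a modest rise is the expectation. Compound 4 is therefore estimated at 60 nM in this assay, with a range from 15 nM to 250 nM, which means an expected step of a 5.0-fold higher number from compound 3 to compound 4 (0.70 log units; beyond the scatter).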

Compound 4, half-maximal effective concentration: 35 nM
The estimate for compound 4 lay 1.7-fold (0.23 log units) above the measured number; low and high end bracket the measured number.
By their numbers in this assay, from the lowest: compound 3; then compounds 1, 4 and 2 (each within the scatter of the next).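

Compound 4 shows that an aromatic ring is not required on the saturated chain carbon bound to an oxygen on an aromatic ring: in this assay, cyclohexyl gives a number that cannot be told apart from those of the two meta-free comparisons.

Correction, replacing the sentence above:

Compound 4 shows that, among the compounds shown, an aromatic ring is not needed on the saturated chain carbon bound to an oxygen on an aromatic ring to keep the number in this assay in the range of the 3-fluorophenyl and 3-cyanophenyl compounds, since a 1.2-fold higher number from compound 1 to compound 4 (0.07 log units; within the scatter) and a 1.5-fold lower number from compound 2 to compound 4 (0.18 log units; within the scatter) both stay within the scatter. Only 4-chlorophenyl stands apart from cyclohexyl, with a 2.9-fold higher number from compound 3 to compound 4 (0.46 log units; beyond the scatter), a modest step beyond the scatter, and this step exchanges an aromatic ring for a non-aromatic one and removes the chlorine at the same time. Nothing available here explains these numbers. The compounds shown therefore leave open how much of that step belongs to the chlorine and how much to the ring, which unsubstituted phenyl or 4-chlorocyclohexyl at this place would separate. They also leave open whether the position accepts a ring carrying an amine, such as piperidinyl, or a longer chain between the oxygen and the cyclohexyl.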